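Cytotoxicity notes: pyrrolylphenyl oxadiazole and hydrazide pair

A few compounds are considered here, and "the series" means these few. Any claim that something is new, unique, unknown or untested is made for them only; others in the source may bear on it.

Measured so far:
compound 1 `c1ccc(-c2nnc(-c3ccc(-n4cccc4)cc3)o2)cc1` — 250000 nM
compound 2 `O=C(NNC(=O)c1ccc(-n2cccc2)cc1)c1ccccc1` — 200000 nM

In an ADME assay on Vero cells (Chlorocebus sabaeus) for cytotoxicity, read by MTT assay, with a stated time of 72 h (on this read-out higher numbers stand for weaker inhibition and lower numbers for stronger inhibition), compound 1 gives 250000 nM, the highest of the two numbers; compound 2 gives 200000 nM, which lies within the scatter, so the two are not told apart.

Compound 3 `O=[N+]([O-])c1cccc(-c2nnc(-c3ccc(-n4cccc4)cc3)o2)c1` carries nitro in place of hydrogen on an aromatic carbon relative to compound 1. Within the data shown here, no step between measured compounds is at hand for this change, so nothing beyond the scatter is expected in this assay, in either direction. Compound 3 is therefore estimated at 200000 nM, range 80000 nM to 400000 nM, a step of a 1.3-fold lower number from compound 1 to compound 3 (0.10 log units; within the scatter).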

Compound 3, half-maximal inhibitory concentration: 251000 nM
Compound 3: middle estimate off by 1.3-fold (0.10 log units), on the low side; measured number inside the range.
By their numbers in this assay, from the lowest: compounds 2, 1 and 3 (each within the scatter of the next).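

In this assay, nitro in place of hydrogen on an aromatic carbon, meta to a large group, gives a 1.0-fold higher number from compound 1 to compound 3 (0.00 log units; within the scatter). The earlier compounds shown here held no substituent on this ring, and the 3 heavy atoms of nitro here leave compound 1 and compound 3 not told apart. No measurement at hand offers a reason for this result.

On these data alone, whether an amine or a carboxylic acid at this position would read the same remains open. Also open, as far as these compounds go, is whether nitro on compound 2 would leave its number within the scatter.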